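A few compounds are considered here, and "the series" means these few. Any claim that something is new, unique, unknown or untested is made for them only; others in the source may bear on it.

Measured so far:
Compound 1, `c1ccc(-c2cc3n(n2)CCCC3)nc1` — 1290 nM
Compound 2, `Cc1ccc(-c2cc3n(n2)CCCC3)nc1` — 3000 nM

In a functional assay on HEK293 cells for negative allosteric modulation of metabotropic glutamate receptor 5 (Rattus norvegicus), read by FLIPR and calcium flux, with a stated time of 170 s (on this read-out higher numbers stand for weaker inhibition and lower numbers for stronger inhibition), compound 1 gives 1290 nM, the lowest number of the two measured compounds. Its nearest neighbour is compound 2, which in this assay gives 3000 nM. Going by the values given here, the one measured step, a 2.3-fold higher number from compound 1 to compound 2 (0.37 log units; beyond the scatter), is modest.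

Compound 3 is `Cc1cccc(-c2cc3n(n2)CCCC3)n1`. It differs from compound 1 by methyl in place of hydrogen on an aromatic carbon. Among the compounds with values here, the only measured step that bears on this change is the one from compound 1 to compound 2, where a methyl also enters on an aromatic carbon of the same ring, though at a different place, and that step gave a modestly higher number. On that basis a methyl in compound 3 is expected to give a number of similar or slightly higher size than compound 1, or one within the scatter. The estimate for compound 3 in this assay is 2500 nM, ranging from 900 nM to 7000 nM, a step of a 1.9-fold higher number from compound 1 to compound 3 (0.29 log units; within the scatter).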

Compound 3, half-maximal inhibitory concentration: 1240 nM
Estimate against measurement, compound 3: 2.0-fold (0.30 log units) above; measured number inside the range.
By their numbers in this assay, from the lowest: compounds 3 and 1 (each within the scatter of the next); then compound 2.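

In this assay, a methyl placed next to the ring nitrogen gives a 1.0-fold lower number from compound 1 to compound 3 (0.02 log units; within the scatter), so at this place the added carbon leaves no readable mark on the number. The earlier step, with a methyl at another place on the same ring, was a 2.3-fold higher number from compound 1 to compound 2 (0.37 log units; beyond the scatter) and lay beyond the scatter, which shows that on this ring the same small group does not act alike at these two places. No measurement shown here gives a reason for this difference.

The compounds shown leave open whether a longer chain such as ethyl, or a different group such as an amine or methoxy, would also leave the number unmoved next to the ring nitrogen. They also leave open whether any group at this place can bring the number lower.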